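Amide side chain exchange on the shared core

The source may report more compounds than this note shows. Statements on the series, on what has been measured and on what is new or still open speak of the compounds shown alone.

Three compounds have a reading in a functional assay on HT-29 cells (Homo sapiens) for antiproliferative activity, read by MTT assay, with a stated time of 72 h, tested at 10 uM; a higher number here means more inhibition at the concentration tested (going by the name of the read-out), a lower number less inhibition. Compound 1 `Cn1cc(-c2ccc(F)cc2)c(=O)c2c(Nc3ccc(Oc4ccnc(NC(=O)C5CC5)c4)c(F)c3)nccc21` gives 24.8%. Compound 3 `CC(C)(O)Cn1cc(-c2ccc(F)cc2)c(=O)c2c(Nc3ccc(Oc4ccnc(NC(=O)C5CC5)c4)c(F)c3)nccc21` gives -2.6%. Compound 2 `CCCCC(=O)Nc1cc(Oc2ccc(Nc3nccc4[nH]cc(-c5ccc(F)cc5)c(=O)c34)cc2F)ccn1` gives -42.2%, the lowest of the three numbers, with compound 3 nearest and compound 1 furthest, both gaps beyond the scatter. Among the measured compounds shown here, the only step between measured compounds that differ in a single place is a number 27.4 percentage points lower from compound 1 to compound 3 (beyond the scatter), a modest fall on bringing in a hydroxyl-bearing group. Compound 4 `CC(O)C(=O)Nc1cc(Oc2ccc(Nc3nccc4[nH]cc(-c5ccc(F)cc5)c(=O)c34)cc2F)ccn1` is not yet measured. For the measured compounds named here, it differs from compound 2 as follows: 1-hydroxyethyl in place of butyl on a carbonyl carbon No measured pair tests a change on the carbonyl carbon of the amide, so the step from compound 1 to compound 3 is the sole guide, and it bears only loosely: it likewise introduces a hydroxyl-bearing group, at another place, and lowered the read-out. A small step, likely within the scatter, is therefore expected, a number 7.2 percentage points higher from compound 2 to compound 4 (within the scatter). For compound 4 in this assay the estimate is -35%, expected to fall between -70% and 5%.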

Compound 4, a percentage reported as inhibition, at one concentration (the size of the read-out at that concentration, not a potency): 47.8%
Beside the measured number, compound 4's estimate is 82.8 percentage points below it; measured number above the stated range.
By their numbers in this assay, from the lowest: compound 2; then compound 3; then compound 1; then compound 4.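

Among the compounds shown here, on the carbonyl carbon, 1-hydroxyethyl in place of butyl gives a number 90 percentage points higher from compound 2 to compound 4 (beyond the scatter) in this assay, the first measured step at this position and a large one, so the read-out depends strongly on this amide side chain. The other step that brings in a hydroxyl-bearing group, a number 27.4 percentage points lower from compound 1 to compound 3 (beyond the scatter), sits at another place and runs the opposite way, so its direction does not carry over to this position. Nothing at hand accounts for the size of the step from butyl to 1-hydroxyethyl.

This change alters the chain and adds the hydroxyl together, and the compounds shown do not separate the two; a propyl group on the same carbonyl carbon would help to do so. Also open, as far as these compounds go, is how an amine or a methoxy group in place of the hydroxyl would read in this assay.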